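Replacing the 4-hydroxyphenyl group of compound 3

The source may report more compounds than this note shows. Statements on the series, on what has been measured and on what is new or still open speak of the compounds shown alone.

Values so far in a physicochemical assay for lipophilicity, measured as octanol-water partition; a lower number here means a more polar compound, a higher number a more lipophilic compound:
- compound 1 `O=C(NNc1ccnc2cc(Cl)ccc12)c1ccccc1/N=C/c1ccccc1Cl` gives 5.5
- compound 2 `O=C(NNc1ccnc2cc(Cl)ccc12)c1ccccc1/N=C/c1ccc(Br)cc1` gives 5.76
- compound 3 `O=C(NNc1ccnc2cc(Cl)ccc12)c1ccccc1/N=C/c1ccc(O)cc1` gives 4.65

Compound 3 stands lowest of the three. Compound 4 `O=C(NNc1ccnc2cc(Cl)ccc12)c1ccccc1/N=C/c1cc2ccccc2[nH]c1=O` keeps the shared core and differs from compound 3 in one place: a group of 11 heavy atoms (9 carbon, 1 nitrogen, 1 oxygen; one six-membered aromatic ring of carbon only, one six-membered aromatic ring with 1 hetero atom) in place of a group of 7 heavy atoms (6 carbon, 1 oxygen; one six-membered aromatic ring of carbon only), on a carbon with a double bond to nitrogen is the whole change. Measured swaps at that place show how far the number can move: a number 0.85 log units lower from compound 1 to compound 3 (beyond the scatter) and a number 1.11 log units lower from compound 2 to compound 3 (beyond the scatter) are clear steps, whereas a number 0.26 log units higher from compound 1 to compound 2 (within the scatter) is not. Within the data shown here, no measured compound carries the entering group, so only a moderate rise is expected, towards compound 1 and compound 2. For compound 4 the estimate is 5 with an expected range from 4.5 to 5.5 as the likely span. That means an expected a number 0.35 log units higher from compound 3 to compound 4 (beyond the scatter) in this assay and no larger.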

Compound 4, partition coefficient: 4.65
For compound 4 the middle estimate is 0.35 log units above the measured one, and the stated range covers the measured number.
By their numbers in this assay, from the lowest: compounds 3 and 4 (each within the scatter of the next); then compounds 1 and 2 (each within the scatter of the next).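

In this assay, the larger two-ring group at this carbon with a double bond to nitrogen gives no change at the digits printed from compound 3 to compound 4 (within the scatter), so here a bigger group did not by itself move the number. Compound 4 stays apart from the 2-chlorophenyl and 4-bromophenyl compounds, with a number 0.85 log units lower from compound 1 to compound 4 (beyond the scatter) and a number 1.11 log units lower from compound 2 to compound 4 (beyond the scatter) as clear steps. Nothing available here gives a reason for this result. The compounds shown leave open how a 4-aminophenyl or 4-carboxyphenyl group would behave at this place, and whether a 4-methoxyphenyl group would stay with compound 3 and compound 4 or move towards compound 1 and compound 2.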